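This account rests on a few compounds, and the source may have more. Where it says the series, first, only, none or still open, it means among the compounds named here.

Compound 1 `O=C(CCCCC1CCSS1)Nc1ccc(Cl)cn1`: 68.6%
Compound 2 `O=C(CCCCC(S)CCS)Nc1ccc(F)cc1`: 22.3%

In a functional assay on HO8910 cells (Homo sapiens) for inhibition, read by MTT assay, with a stated time of 24 h, tested at 100 ug/mL (a higher number here means more inhibition of growth at the concentration tested, a lower number less inhibition of growth), compound 2 gives 22.3%, the lower of the two numbers. Compound 1 gives 68.6%, and this gap lies beyond the usual scatter of repeated measurements. Among the compounds with values here, the two measured compounds do not differ in just one place, so the data contain no clean single-change step to learn from.

Compound 3 `O=C(CCCCC(S)CCS)Nc1ccc([N+](=O)[O-])cc1` keeps the structure of compound 2 except for one group, with nitro in place of fluoro on an aromatic carbon, para to a large group: nitro in place of fluoro on an aromatic carbon. With so little data, only a small upward change is expected, and it may well stay within the scatter. The expected size of this change is a number 7.7 percentage points higher from compound 2 to compound 3 (within the scatter). In this assay, compound 3 is estimated at 30%, with an expected range of 14% to 50%.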

Compound 3, percent growth inhibition at one concentration: 51.2%
The estimate for compound 3 lay 21.2 percentage points below the measured number; measured number outside the range, above it.
By their numbers in this assay, from the lowest: compound 2; then compound 3; then compound 1.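

In this assay, putting nitro in place of fluoro on the aromatic carbon, para to a large group, gives the first clean single-change step among these compounds: a number 28.9 percentage points higher from compound 2 to compound 3 (beyond the scatter). This shows that the group at this position matters, since the change is larger than repeated measurements would normally produce. No available measurement explains why the number moves, so the step stands as an observation only.

The compounds shown leave open whether this rise is particular to nitro or would also appear with another group at the same place, such as an amine, a nitrile or a carboxylic acid. As far as these compounds go, it is also open whether the same exchange would move the number in the same direction on a different core, such as the core of compound 1.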